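Fluoro for methoxy on the phenyl ring of compound 2

The source may hold more compounds than are shown below. What is called first, only, known or untested is meant among the compounds shown, and "the series" means these compounds.

Two compounds have been measured in a functional assay on EKVX cells (Homo sapiens) for inhibition, read by sulforhodamine B assay, with a stated time of 48 h, tested at 10 uM; a lower number here means less inhibition, a higher number more inhibition at the concentration tested (going by the name of the read-out):

Compound 1, `c1ccc(-c2cn3ccnc3c(-c3ccc4ncn(C5CCCCC5)c4c3)n2)cc1`: 24.2%
Compound 2, `COc1ccc(-c2cn3ccnc3c(-c3ccc4ncn(C5CCCCC5)c4c3)n2)cc1`: 56.7%

Among the measured compounds shown here, compound 2 stands highest of these two numbers, and the only step between them, a number 32.5 percentage points higher from compound 1 to compound 2 (beyond the scatter), came with methoxy in place of hydrogen on an aromatic carbon. Compound 3, `Fc1ccc(-c2cn3ccnc3c(-c3ccc4ncn(C5CCCCC5)c4c3)n2)cc1`, now changes the same position again: fluoro in place of methoxy on an aromatic carbon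

For the measured compounds named here, no measured step joins methoxy and fluoro directly, so the step from compound 1 to compound 2 is the only guide. It shows that the same aromatic carbon with nothing but hydrogen gives the lower number, and fluoro is by the counts shown closer to hydrogen than to methoxy. A drop from compound 2, smaller than the rise seen before, is therefore expected, a number 21.7 percentage points lower from compound 2 to compound 3 (beyond the scatter). Compound 3 is estimated at 35%, with a range from 15% to 58%.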

Compound 3, a percentage reported as inhibition, at one concentration (the size of the read-out at that concentration, not a potency): 10.5%
Beside the measured number, compound 3's estimate is 24.5 percentage points above it, and the stated range ends above it.
By their numbers in this assay, from the lowest: compound 3; then compound 1; then compound 2.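

At this position on the phenyl ring, replacing hydrogen does not always raise the number in this assay: fluoro in place of hydrogen gives a number 13.7 percentage points lower from compound 1 to compound 3 (beyond the scatter), the opposite direction to the rise seen with methoxy. Fluoro in place of methoxy gives a number 46.2 percentage points lower from compound 2 to compound 3 (beyond the scatter), so these two groups on the same aromatic carbon fall on opposite sides of hydrogen. No separate evidence bears on why they part in this way.

With only hydrogen, methoxy and fluoro at this position, the compounds shown cannot tell what an amine, a hydroxyl or a longer chain such as ethoxy would do there. From the compounds shown here alone, it also remains open whether the same order of the three groups would hold with a change elsewhere on the shared core.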